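Anilino series: iodo for ethyl on the aryl ring

This account rests on a few compounds, and the source may have more. Where it says the series, first, only, none or still open, it means among the compounds named here.

Compound 3 `CCc1ccc(NC2=CC(=O)c3c(nc4n3[C@H]3OC[C@@H](O)[C@H]3OC4)C2=O)cc1` gives 1110 nM in a functional assay on MGC-803 cells (Homo sapiens) for inhibition, read by sulforhodamine B assay (on this read-out higher numbers stand for weaker inhibition and lower numbers for stronger inhibition), the lowest of the two numbers at hand; its nearest neighbour is compound 1 `O=C1C(Nc2cccc(Cl)c2)=CC(=O)c2c1nc1n2[C@H]2OC[C@@H](O)[C@H]2OC1`, which in this assay gives 1530 nM, a gap within the scatter, so the two are not ordered. Compound 2 `O=C1C(N2CCCC2)=CC(=O)c2c1nc1n2[C@H]2OC[C@@H](O)[C@H]2OC1` reaches only a limit in this assay, > 16000 nM, which is the limit of > 16000 nM in this assay, at which 1 of the 3 values shown sits.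

Two of the measured steps concern the group on the double-bonded ring carbon: an at least 10-fold higher number from compound 1 to compound 2 (1.01 log units; beyond the scatter) and an at least 14-fold lower number from compound 2 to compound 3 (1.15 log units; beyond the scatter), both large, and both tied to the exchange between an arylamino group and pyrrolidin-1-yl. The third, a 1.4-fold lower number from compound 1 to compound 3 (0.14 log units; within the scatter), changes only the aryl ring of the arylamino group and stays within the scatter.

Compound 4 `O=C1C(Nc2ccc(I)cc2)=CC(=O)c2c1nc1n2[C@H]2OC[C@@H](O)[C@H]2OC1` differs from compound 3 by iodo in place of ethyl on an aromatic carbon. The arylamino group is kept, and the change is of the kind seen in the step from compound 1 to compound 3, a swap of the substituent on the aryl ring, which did not move the number beyond the scatter. For compound 4, therefore, the expected step is a 1.1-fold higher number from compound 3 to compound 4 (0.03 log units; within the scatter), with no direction beyond the scatter. Compound 4 is estimated at 1200 nM in this assay, with a range of 500 nM to 3000 nM.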

Compound 4, half-maximal inhibitory concentration: 2150 nM
Compound 4: the middle estimate sits 1.8-fold (0.25 log units) below what was measured, within the range that was stated.
By their numbers in this assay, from the lowest: compounds 3, 1 and 4 (each within the scatter of the next). At a limit, above all of these: compound 2.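

Iodo in place of ethyl on the aromatic carbon gives a 1.9-fold higher number from compound 3 to compound 4 (0.29 log units; within the scatter), and 4-iodophenyl in place of 3-chlorophenyl on the amine nitrogen gives a 1.4-fold higher number from compound 1 to compound 4 (0.15 log units; within the scatter), so compounds 1, 3 and 4 stand unordered in this assay across 4-ethylphenyl, 3-chlorophenyl and 4-iodophenyl. The exchange with pyrrolidin-1-yl on the double-bonded ring carbon now holds for a third aryl ring as well, with an at least 7.4-fold lower number from compound 2 to compound 4 (0.87 log units; beyond the scatter), so among the compounds shown the large steps follow the swap of the arylamino group, and no swap on the aryl ring has yet moved the number beyond the scatter. Compound 2 remains a limit, not a number, so that step has only a bound: the limit of > 16000 nM in this assay, at which 1 of the 4 values shown sits.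

Still open, on these data alone, is whether any group on the aryl ring, such as a carboxylic acid, a dimethylamino group or a longer alkyl chain, would give a step beyond the scatter. Also open, as far as these compounds go, is whether other groups on the double-bonded ring carbon, such as morpholin-4-yl or benzylamino, would read like compound 2 or like the arylamino compounds.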